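The source may hold more compounds than are shown below. What is called first, only, known or untested is meant among the compounds shown, and "the series" means these compounds.

Of the compounds shown here, three of a shared core have been measured in a functional assay on MDA-MB-231 cells (Homo sapiens) for cytotoxicity, read by MTT assay, with a stated time of 24 h; a lower number here means a stronger inhibitor, a higher number a weaker inhibitor. Compound 1 `Cc1cc(O)c(C(=O)/C=C/c2ccccc2Cl)c(-c2ccc(Cl)cc2)c1C(=O)/C=C/c1ccccc1Cl` gives 29000 nM. Compound 2 `Cc1cc(O)c(C(=O)/C=C/c2ccccc2)c(-c2ccc(Cl)cc2)c1C(=O)/C=C/c1ccccc1` gives 4400 nM. Compound 3 `COc1ccc(/C=C/C(=O)c2c(C)cc(O)c(C(=O)/C=C/c3ccc(OC)cc3)c2-c2ccc(OCc3ccccc3)cc2)cc1` gives 12000 nM. Among these three numbers compound 2 has the lowest, and both gaps from it, to compound 3 and to compound 1, lie beyond the usual scatter, so compound 2 is the strongest inhibitor of the three in this assay.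

Compound 4 `Cc1cc(O)c(C(=O)/C=C/c2ccccc2)c(-c2ccccc2)c1C(=O)/C=C/c1ccccc1` has not yet been measured. It differs from compound 2 in one place: hydrogen in place of chloro on an aromatic carbon, on an aromatic carbon of a six-membered aromatic ring of carbon only, para to a large group; cut one bond further out, the change reads as 4-chlorophenyl to phenyl. For the measured compounds named here, no pair of measured compounds shows this exact change on its own, so there is no measured step to lean on. The expectation is a modest weakening, a 1.4-fold higher number from compound 2 to compound 4 (0.13 log units; within the scatter), close to the edge of the scatter. The estimate for compound 4 in this assay is therefore 6000 nM, within a range from 2000 nM to 18000 nM.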

Compound 4, half-maximal inhibitory concentration: 8500 nM
For compound 4 the middle estimate is 1.4-fold (0.15 log units) below the measured one, and the stated range covers the measured number.
By their numbers in this assay, from the lowest: compounds 2, 4 and 3 (each within the scatter of the next, the first and the last beyond it); then compound 1.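

In this assay, for the compounds shown here, the change from 4-chlorophenyl to phenyl gives a 1.9-fold higher number from compound 2 to compound 4 (0.29 log units; within the scatter) and is the first single-place comparison on the shared core, since compound 1 and compound 3 each differ from compound 2 in more than one place. The assay therefore does not separate compound 2 from compound 4, so at this position the chloro is not shown to matter, and losing this one heavy atom leaves the number within ordinary repeat variation. No measurement shown here accounts for this result.

What the compounds leave open is whether a larger or differently built group at this position, such as an amine, a carboxylic acid or a longer carbon chain, would separate from hydrogen and chloro. Going by these compounds, it also remains open whether the same swap would give a similar result with the other side chains carried by compound 1 or compound 3.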